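Iodo in Place of Fluoro: Expected Potency of Compound 4

The compounds below may be only part of what the source reports. "The series", "measured", "known", "first", "only" and "open" are said of these compounds alone.

Compound 2 `CC#C[C@@H](Cc1nnn[nH]1)c1ccc(OCc2ccc3sc(F)c(-c4ccccc4C)c3c2)cc1` gives 14 nM in a functional assay on cells for agonist activity at Free fatty acid receptor 1 (Rattus norvegicus), read by FLIPR and calcium flux; a lower number here means that less compound is needed, a higher number that more compound is needed for the effect; compound 1 `CC#C[C@@H](Cc1nnn[nH]1)c1ccc(OCc2ccc3scc(-c4cccnc4C)c3c2)cc1` gives 20 nM and compound 3 `CC#C[C@@H](Cc1nnn[nH]1)c1ccc(OCc2ccc3sc(F)c(-c4ccc(OCCOC)cc4C)c3c2)cc1` gives 24 nM, both within the scatter of compound 2. Among the measured compounds shown here, the one single-point step among the measured compounds, a 1.7-fold higher number from compound 2 to compound 3 (0.23 log units; within the scatter), concerns a 2-methoxyethoxy group on the 2-methylphenyl ring and stays within the scatter. Compound 4 `CC#C[C@@H](Cc1nnn[nH]1)c1ccc(OCc2ccc3sc(I)c(-c4ccccc4C)c3c2)cc1` differs from compound 2 by iodo in place of fluoro on an aromatic carbon. For the measured compounds named here, no measured step touches this position, so nothing in the set bears directly on the exchange, and the step is expected to stay within the scatter, with no direction favoured. Compound 4 is therefore expected to give 20 nM in this assay, between 6 nM and 70 nM. The step this estimate means, a 1.4-fold higher number from compound 2 to compound 4 (0.15 log units; within the scatter), is expected to lie within the scatter.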

Compound 4, half-maximal effective concentration: 33 nM
Beside the measured number, compound 4's estimate is 1.7-fold (0.22 log units) below it, and the stated range covers the measured number.
By their numbers in this assay, from the lowest: compounds 2, 1, 3 and 4 (each within the scatter of the next, the first and the last beyond it).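

In this assay, iodo in place of fluoro on this aromatic carbon, next to the ring sulfur, gives the only step shown that lies beyond the scatter (a 2.4-fold higher number from compound 2 to compound 4 (0.37 log units; beyond the scatter)). The position therefore responds to this exchange of halogens, though the step is modest and compound 4 keeps agonist activity. Nothing available accounts for the step. Going by these compounds, what an amine, a nitrile or a methyl group would give at this position remains open. So does whether the same exchange gives a similar step when the 2-methylphenyl group carries 2-methoxyethoxy.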